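Butoxy for isopropyl on the chalcone ring

A few compounds are considered here, and "the series" means these few. Any claim that something is new, unique, unknown or untested is made for them only; others in the source may bear on it.

Compound 2 `CC(C)c1ccc(O)c(C(=O)/C=C/c2ccc(O)c(O)c2)c1`: 4 nM
Compound 1 `Cc1ccc(O)c(C(=O)/C=C/c2ccc(O)c(O)c2)c1`: 39 nM

In an assay on RBL-1 cells for inhibition of Polyunsaturated fatty acid 5-lipoxygenase (Rattus norvegicus) (a higher number here means a weaker inhibitor, a lower number a stronger inhibitor), compound 2 gives 4 nM, the lowest of the two numbers shown, with compound 1 the nearest at 39 nM. Compound 3 `CCCCOc1ccc(O)c(C(=O)/C=C/c2ccc(O)c(O)c2)c1` carries the change (butoxy in place of isopropyl on an aromatic carbon). Going by the values given here, the one step that bears on it is a 9.8-fold lower number from compound 1 to compound 2 (0.99 log units; beyond the scatter), where a larger alkyl group gave a lower number. Butoxy is larger still but brings an oxygen, for which no measured step exists, so only a small step, if any, is expected in this assay. Compound 3 is estimated at 6 nM, within 1.5 nM to 25 nM, a step of a 1.5-fold higher number from compound 2 to compound 3 (0.18 log units; within the scatter).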

Compound 3, half-maximal inhibitory concentration: 1000 nM
For compound 3 the middle estimate is 170-fold (2.22 log units) below the measured one; the whole stated range lies below it.
By their numbers in this assay, from the lowest: compound 2; then compound 1; then compound 3.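

Butoxy breaks the direction seen so far at this aromatic carbon, para to a hydroxy group: in this assay the change gives a 250-fold higher number from compound 2 to compound 3 (2.40 log units; beyond the scatter), and the comparison with the smallest group gives a 26-fold higher number from compound 1 to compound 3 (1.41 log units; beyond the scatter), so compound 3 has the highest number of the three. The gain seen with isopropyl therefore does not extend to every larger group here. Nothing available accounts for this reversal.

The compounds shown leave open whether the higher number goes with the ether oxygen or with the chain length. A methoxy group or a plain butyl chain on the same carbon would separate the two.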